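The compounds below may be only part of what the source reports. "The series", "measured", "known", "first", "only" and "open" are said of these compounds alone.

Measured compounds:

- compound 1, `C[C@H]1CC[C@@H]2[C@@H](OC(=O)[C@]23CC(c2ccc(F)cc2)=NO3)[C@]2(C)C(=O)C=C[C@@]12O`: 1.58
- compound 2, `C[C@H]1CC[C@@H]2[C@@H](OC(=O)[C@]23CC(c2ccc(C#N)cc2)=NO3)[C@]2(C)C(=O)C=C[C@@]12O`: 1.17
- compound 3, `C[C@H]1CC[C@@H]2[C@@H](OC(=O)[C@]23CC(c2ccc(F)cc2)N(c2ccccc2)O3)[C@]2(C)C(=O)C=C[C@@]12O`: 3.35

All three values come from a physicochemical assay for lipophilicity; on this read-out lower numbers stand for lower lipophilicity and higher numbers for higher lipophilicity. Compound 1 and compound 2 share one core and differ in a single place: cyano in place of fluoro on an aromatic carbon. This change gave a number 0.41 log units lower from compound 1 to compound 2 (beyond the scatter). Compound 3 carries a different core; the difference between the two cores is not broken down here. In this assay compound 3 stands highest of the three, and its gap to compound 1 and to compound 2 lies beyond the scatter.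

Compound 4, `C[C@H]1CC[C@@H]2[C@@H](OC(=O)[C@]23CC(c2ccc(C#N)cc2)N(c2ccccc2)O3)[C@]2(C)C(=O)C=C[C@@]12O`, is not yet measured. It is compound 3 after the same single change: cyano in place of fluoro on an aromatic carbon. The place description is identical word for word to that of the change from compound 1 to compound 2, so this is the same change, made once on each core; it occurs twice among the compounds shown.

For the measured compounds named here, with only one measured instance of the change, the expectation for compound 4 rests on that one step. Going by the values given here, the step from compound 3 to compound 4 is expected to be about as large as the one from compound 1 to compound 2, because a number 0.41 log units lower from compound 1 to compound 2 (beyond the scatter) is the sole precedent, giving an estimated a number 0.40 log units lower from compound 3 to compound 4 (beyond the scatter) in this assay. The value for compound 4 is thus estimated at 2.95, with a likely range from 2.55 to 3.35; the transfer of a step to a different core is not checked by any measured pair here, so the range is kept wide.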

Compound 4, partition coefficient: 2.94
Estimate against measurement, compound 4: 0.01 log units above; the range from low to high includes it.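

In this assay compound 3 gives 3.35 and compound 4 gives 2.94 after the exchange of 4-fluorophenyl for 4-cyanophenyl, which reads as a number 0.41 log units lower from compound 3 to compound 4 (beyond the scatter) and matches in size and direction the step on the other core, a number 0.41 log units lower from compound 1 to compound 2 (beyond the scatter). For these two cores, then, the step carried over intact, and its size did not depend on which of the two cores bore the change. This is one change on one pair of cores, so it sets no rule for any further core, and nothing measured here bears on why the step has this size or why it held across both cores.

The compounds shown hold only fluoro and cyano on this aromatic carbon, so it stays open whether a step taken from one core would also carry over for another group there, such as an amine or a carboxylic acid. Going by these compounds, it also stays open whether the agreement seen with cyano in place of fluoro would survive on a third core, or on a core carrying a longer chain in place of the phenyl of compound 3.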